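Fluoro to chloro between compound 2 and compound 3

The source may hold more compounds than are shown below. What is called first, only, known or untested is meant among the compounds shown, and "the series" means these compounds.

Measured so far in an ADME assay on MCF7 cells (Homo sapiens) for cytotoxicity, read by MTT assay, with a stated time of 48 h; a lower number here means a stronger inhibitor, a higher number a weaker inhibitor:
compound 1 `Clc1ccc(-c2[nH]c3cc(Cl)ccc3c2Cn2ccnc2)cc1`: > 1000000 nM
compound 2 `Fc1ccc(-c2[nH]c3cc(Cl)ccc3c2Cn2cncn2)cc1`: 625000 nM

Compound 1 has the entry > 1000000 nM, which is a limit of the assay and not a number. Among the compounds with values here, that leaves compound 2, at 625000 nM, as the only true number available in this assay.

The next compound to be tested is compound 3 `Clc1ccc(-c2[nH]c3cc(Cl)ccc3c2Cn2cncn2)cc1`. It keeps the structure of compound 2 apart from one change: chloro in place of fluoro on an aromatic carbon, turning 4-fluorophenyl into 4-chlorophenyl. Within the data shown here, no measured pair isolates this change, so compound 2 at 625000 nM is the sole anchor. No shift beyond the usual scatter is expected in this assay, and no direction is favoured. The estimate implies an expected step of a 1.0-fold higher number from compound 2 to compound 3 (0.02 log units; within the scatter). Compound 3 is estimated at 650000 nM, within an expected range of 300000 nM to 1400000 nM.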

Compound 3, half-maximal inhibitory concentration: 382000 nM
Estimate against measurement, compound 3: 1.7-fold (0.23 log units) above; low and high end bracket the measured number.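

In this assay, within the data shown here, the first exchange at the aromatic carbon para to a large group, chloro in place of fluoro, gives a 1.6-fold lower number from compound 2 to compound 3 (0.21 log units; within the scatter), so at this position the two halogens cannot be told apart. Compound 1 has the entry > 1000000 nM, which is a limit of the assay and not a number. With the chloro held fixed, 1H-1,2,4-triazol-1-yl in place of 1H-imidazol-1-yl gives an at least 2.6-fold lower number from compound 1 to compound 3 (0.41 log units; beyond the scatter), the first step here beyond the scatter, though its true size stays unknown and only a floor can be read: the limit of > 1000000 nM in this assay, at which 1 of the 3 values shown sits.

The compounds shown leave open whether a group other than a halogen at this position, such as methoxy or an amine, would move the number beyond the scatter. They also leave open how the triazole compares with the imidazole when fluoro is held fixed.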